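A few compounds are considered here, and "the series" means these few. Any claim that something is new, unique, unknown or untested is made for them only; others in the source may bear on it.

In a functional assay on HCT-116 cells (Homo sapiens) for cytotoxicity (a higher number here means a weaker inhibitor, a lower number a stronger inhibitor), compound 2 `CCCCCCCCC[C@@H]1CC(=O)N[C@H](CC(C)C)C(=O)N[C@@H](CO)C(=O)N[C@@H]([C@@H](C)O)C(=O)N[C@H](CC(C)C)C(=O)N[C@@H]([C@@H](C)CC)C(=O)O1` gives 22000 nM, the lowest of the two numbers recorded. Compound 3 `CC[C@H](C)[C@@H]1NC(=O)[C@@H](CC(C)C)NC(=O)[C@H]([C@@H](C)O)NC(=O)[C@H](CO)NC(=O)[C@@H](CC(C)C)NC(=O)C[C@@H](CCCCCCC(C)C)OC1=O` gives 50000 nM in this assay, and the step of a 2.3-fold higher number from compound 2 to compound 3 (0.36 log units; beyond the scatter) is the only measured one. For compound 1 `CCCCCCC[C@@H]1CC(=O)N[C@H](CC(C)C)C(=O)N[C@@H](CO)C(=O)N[C@@H]([C@@H](C)O)C(=O)N[C@H](CC(C)C)C(=O)N[C@@H]([C@@H](C)CC)C(=O)O1` this assay gives "not determined" (no result reported). Compound 4 `CCCCCC/C=C\CCC[C@@H]1CC(=O)N[C@H](CC(C)C)C(=O)N[C@@H](CO)C(=O)N[C@@H]([C@@H](C)O)C(=O)N[C@H](CC(C)C)C(=O)N[C@@H]([C@@H](C)CC)C(=O)O1` differs from compound 2 as follows: a group of 8 heavy atoms (8 carbon; no ring) in place of a group of 6 heavy atoms (6 carbon; no ring), on a saturated chain carbon, three bonds along the chain from a saturated ring carbon. Within the data shown here, no measured step alters this part of the chain; the one step known, a 2.3-fold higher number from compound 2 to compound 3 (0.36 log units; beyond the scatter), concerns a different place and was modest, so a step of comparable or smaller size, in either direction, is all that can be expected from compound 2 to compound 4, estimated as a 1.1-fold lower number from compound 2 to compound 4 (0.04 log units; within the scatter). Compound 4 is therefore estimated at 20000 nM, within a range of 7000 nM to 60000 nM.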

Compound 4, half-maximal inhibitory concentration: 28000 nM
Compound 4: the middle estimate sits 1.4-fold (0.15 log units) below what was measured; measured number inside the range.
By their numbers in this assay, from the lowest: compounds 2, 4 and 3 (each within the scatter of the next, the first and the last beyond it).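

Putting the group of 8 heavy atoms, with its double bond, in place of hexyl, on a saturated chain carbon, three bonds along the chain from a saturated ring carbon, shows that this change leaves this assay within the scatter, at a 1.3-fold higher number from compound 2 to compound 4 (0.10 log units; within the scatter). The comparison with the branched chain gives a 1.8-fold lower number from compound 3 to compound 4 (0.25 log units; within the scatter), so compound 4 cannot be separated from either neighbour. Nothing available bears on why this chain change gives this result.

Going by these compounds, whether a fully saturated chain of the same length, a trans double bond or a terminal amine on the chain would give a different number remains open.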